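Ring nitrogens on the arylamino arm of a shared core

The source may report more compounds than this note shows. Statements on the series, on what has been measured and on what is new or still open speak of the compounds shown alone.

Compound 1, `COC(=O)c1sc2cc(Nc3ccccc3Br)cnc2c1N`, gives 30900 nM in a functional assay on NCI-H460 cells (Homo sapiens) for inhibition, read by sulforhodamine B assay, with a stated time of 48 h; a lower number here means a stronger inhibitor of growth, a higher number a weaker inhibitor of growth.
Compound 3, `COC(=O)c1sc2cc(Nc3cccnc3)cnc2c1N`, gives 49400 nM in this assay.
Compound 2, `COC(=O)c1sc2cc(Nc3ccccn3)cnc2c1N`, gives only a limit in this assay, > 150000 nM.

Among the numbers that are not limits, compound 3 holds the higher one, but its gap to compound 1 lies within the scatter, a 1.6-fold higher number from compound 1 to compound 3 (0.20 log units; within the scatter). Compound 4, `COC(=O)c1sc2cc(Nc3ncccn3)cnc2c1N`, differs from compound 3 in one place: pyrimidin-2-yl in place of pyridin-3-yl on a nitrogen on an aromatic ring. For the measured compounds named here, two measured steps bear on this. Moving the ring nitrogen into the position next to the amine link gave an at least 4.8-fold higher number from compound 1 to compound 2 (0.68 log units; beyond the scatter), and the reverse comparison gave an at least 3.0-fold lower number from compound 2 to compound 3 (0.48 log units; beyond the scatter), both beyond the scatter. Compound 2 reached only a limit, (the limit of > 150000 nM in this assay, at which 1 of the 3 values shown sits). Since compound 4 carries a ring nitrogen in that same position in its pyrimidin-2-yl group, a weakening beyond the scatter is expected in this assay, of about a 3.0-fold higher number from compound 3 to compound 4 (0.48 log units; beyond the scatter). Compound 4 is therefore estimated at 150000 nM, with a range from 50000 nM to 450000 nM, and a fair chance that only a limit is recorded.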

Compound 4, concentration for 50% growth inhibition: > 150000 nM
Compound 4 was reported as a limit; the forecaster's own chance of this, stated with the estimate: 55%; the middle value lies on the limit itself.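

In this assay, the pyrimidin-2-yl group on a nitrogen on an aromatic ring gives a second case of weakening at this position, seen both in an at least 3.0-fold higher number from compound 3 to compound 4 (0.48 log units; beyond the scatter) and in an at least 4.8-fold higher number from compound 1 to compound 4 (0.68 log units; beyond the scatter). Across the four compounds, the two 2-yl heteroaryl groups, in compound 2 and compound 4, end at the assay limit, while the 2-bromophenyl group of compound 1 and the pyridin-3-yl group of compound 3 give numbers. The step between compound 2 and compound 4 cannot be read, so any further effect of the second ring nitrogen in pyrimidin-2-yl stays hidden: the limit of > 150000 nM in this assay, at which 2 of the 4 values shown sit.

Going by these compounds, what a pyridin-4-yl group or an unsubstituted phenyl group would give at this nitrogen remains open. On these data alone, it is also open whether an amine or a carboxylic acid on the aryl ring would shift growth inhibition in either direction.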